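This account rests on a few compounds, and the source may have more. Where it says the series, first, only, none or still open, it means among the compounds named here.

Within the data shown here, compound 2 `COc1ccc2c(c1)c(C1CCNCC1)cn2S(=O)(=O)c1ccc2cccnc2c1` gives 30 nM in an assay on HEK293 cells for displacement of a labelled ligand from 5-hydroxytryptamine receptor 6 (Homo sapiens), read by scintillation counting (a lower number here means a stronger inhibitor, a higher number a weaker inhibitor), the second highest of the three numbers known here. Compound 3 `COc1ccc2c(c1)c(C1CCNCC1)cn2S(=O)(=O)c1cncc2ccccc12` gives 24 nM, and a 1.3-fold lower number from compound 2 to compound 3 (0.10 log units; within the scatter). Compound 1 `O=S(=O)(c1cc2ccccc2cn1)n1cc(C2=CCNCC2)c2ccc(Cl)cc21` gives 102 nM, but it differs from compound 2 in more than one place, so its gap from compound 2 is not a single step. Compound 4 `CCCN1CC=C(c2cn(S(=O)(=O)c3ccc4cccnc4c3)c3ccc(OC)cc23)CC1` differs from compound 2 in this way: a group of 9 heavy atoms (8 carbon, 1 nitrogen; one six-membered non-aromatic ring with 1 hetero atom) in place of a group of 6 heavy atoms (5 carbon, 1 nitrogen; one six-membered non-aromatic ring with 1 hetero atom), on an aromatic carbon. Among the measured compounds shown here, no measured step changes the same group, so the outcome rests on no direct precedent. The estimate for compound 4 is 60 nM, with a range from 15 nM to 250 nM, meaning an expected step of a 2.0-fold higher number from compound 2 to compound 4 (0.30 log units; within the scatter).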

Compound 4, inhibition constant: 247 nM
Estimate against measurement, compound 4: 4.1-fold (0.61 log units) below; measured number inside the range.
By their numbers in this assay, from the lowest: compounds 3 and 2 (each within the scatter of the next); then compound 1; then compound 4.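

At this position on the shared core, the group on the aromatic carbon matters: swapping piperidin-4-yl for the larger group gives an 8.2-fold higher number from compound 2 to compound 4 (0.92 log units; beyond the scatter) in this assay, whereas the change on the sulfonyl sulfur gave only a 1.3-fold lower number from compound 2 to compound 3 (0.10 log units; within the scatter). Nothing measured here explains this step.

From the compounds shown here alone, the swap adds atoms and a double bond and removes the hydrogen-bond donor all at once, so which of these changes counts remains open. Going by these compounds, how a single methyl group on the nitrogen of piperidin-4-yl would fare also remains open.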